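The source may hold more compounds than are shown below. What is called first, only, known or untested is meant among the compounds shown, and "the series" means these compounds.

Compound 1 `COc1ccc(/C=C2/CN(C)/C(=N/c3ccc(C(C)(C)C)cc3)S2)cc1` gives 25900 nM 
Compound 2 `COc1ccc(/C=C2\S/C(=N\c3ccc(C(C)(C)C)cc3)N(C)C2=O)cc1` gives > 100000 nM 

Within the data shown here, in a functional assay on HCT-116 cells (Homo sapiens) for antiproliferative activity, read by MTT assay, with a stated time of 72 h (on this read-out lower numbers stand for stronger inhibition and higher numbers for weaker inhibition), compound 1 gives 25900 nM as the only actual number so far. Compound 2 reads > 100000 nM and that is a limit of the assay, not a number. Compound 3 `COc1ccc(/C=C2/CN(C)/C(=N/c3ccc([N+](=O)[O-])cc3)S2)cc1` has not been measured; it carries nitro in place of tert-butyl on an aromatic carbon in the frame of compound 1. Among the measured compounds shown here, no measured pair shows this swap, so compound 1 at 25900 nM is the only anchor and no change beyond the usual scatter is expected in this assay here. The expected 1.2-fold lower number from compound 1 to compound 3 (0.07 log units; within the scatter) is therefore small. For compound 3 the estimated value is 22000 nM with a likely range from 7000 nM to 70000 nM in this read-out.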

Compound 3, half-maximal inhibitory concentration: 10200 nM
Compound 3: middle estimate off by 2.2-fold (0.33 log units), on the high side; the measured number falls inside the stated range.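

In this assay, nitro in place of tert-butyl on the aromatic carbon gives a 2.5-fold lower number from compound 1 to compound 3 (0.40 log units; beyond the scatter), so the group at this position can change the read-out, though only modestly here. This rests on a single pair of compounds. Compound 2 has a limit of the assay rather than a number, so it cannot size this change: the limit of > 100000 nM in this assay, at which 1 of the 3 values shown sits.

On these data alone, whether an amine or a carboxylic acid at this position would lower the number further remains open. So does whether the same swap would have any effect in the frame of compound 2.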